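Cytotoxicity notes: swapping the aryl group on the shared core

A few compounds are considered here, and "the series" means these few. Any claim that something is new, unique, unknown or untested is made for them only; others in the source may bear on it.

Compound 1, `Cc1cc(C)cc(-c2cnc(Nc3ccc(C#N)cc3)nc2Oc2c(C)cc(C#N)cc2C)c1`, in an ADME assay on MT4 cells (Homo sapiens) for cytotoxicity, read by MTT assay, with a stated time of 5 days; on this read-out lower numbers stand for higher toxicity in this test and higher numbers for lower toxicity in this test: 39000 nM.
Compound 2, `Cc1cc(C#N)cc(C)c1Oc1nc(Nc2ccc(C#N)cc2)ncc1-c1cncnc1`, gives in this assay only an assay limit: > 298000 nM.

Compound 2 thus stands at the top end of the numbers seen so far, with no exact figure; its value is a limit of the assay, as the line the limit of > 298000 nM in this assay, at which 1 of the 2 values shown sits, records. Among the measured compounds shown here, the only measured step is an at least 7.6-fold higher number from compound 1 to compound 2 (0.88 log units; beyond the scatter), so the direction from an all-carbon aryl group to a diazine on this carbon was toward a higher number.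

Compound 3, `Cc1cc(C#N)cc(C)c1Oc1nc(Nc2ccc(C#N)cc2)ncc1-c1ccc2ccccc2c1`, carries the change (naphthalen-2-yl in place of pyrimidin-5-yl on an aromatic carbon). That reverses the sense of the measured step: a carbon-only bicyclic group replaces the diazine on the same aromatic carbon of the shared core. On the strength of an at least 7.6-fold higher number from compound 1 to compound 2 (0.88 log units; beyond the scatter), a lower number than compound 2 is expected, perhaps at or beyond the level of compound 1, since the new group is larger than the 3,5-dimethylphenyl of compound 1. The step from compound 2 to compound 3 is therefore estimated as an at least 9.9-fold lower number from compound 2 to compound 3 (0.99 log units; beyond the scatter). For compound 3 the expected result in this assay is 30000 nM, within 8000 nM to 150000 nM.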

Compound 3, half-maximal cytotoxic concentration: 8460 nM
Compound 3: the middle estimate sits 3.5-fold (0.55 log units) above what was measured; measured number inside the range.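

In this assay, the change at this aromatic carbon can now be read in both directions: naphthalen-2-yl in place of pyrimidin-5-yl gives an at least 35-fold lower number from compound 2 to compound 3 (1.54 log units; beyond the scatter), so the higher number seen with pyrimidin-5-yl does not persist once a carbon-only group returns. The two carbon-only groups are not equivalent either, as naphthalen-2-yl in place of 3,5-dimethylphenyl gives a 4.6-fold lower number from compound 1 to compound 3 (0.66 log units; beyond the scatter), and the lowest number of the three compounds thus belongs to the group with two aromatic rings. Compound 2 remains a limit of the assay and not a number: the limit of > 298000 nM in this assay, at which 1 of the 3 values shown sits.

Pyrimidin-5-yl differs from both carbon-only groups in its ring nitrogens and also from naphthalen-2-yl in its ring count and heavy atoms, so these compounds do not show which of these differences goes with the change in this assay. Open as well is where a pyridin-3-yl group, with a single ring nitrogen, or a quinolin-3-yl group, with two fused rings and a ring nitrogen, would fall on this carbon.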